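Enantiomer of compound 2 in the antagonist calcium-flux assay

The compounds below may be only part of what the source reports. "The series", "measured", "known", "first", "only" and "open" are said of these compounds alone.

Measured compounds:
compound 1 `C[C@@H](CC(=O)O)CC(=O)c1c([C@@H](O)CCCCCc2ccccc2)n(C)c2ccc(Cl)cc12` gives 120 nM
compound 2 `C[C@H](CC(=O)O)CC(=O)c1c([C@@H](O)CCCCCc2ccccc2)n(C)c2ccc(Cl)cc12` gives 0.38 nM
compound 3 `CC(CC(=O)O)CC(=O)c1c(CCCc2ccccc2)n(C)c2ccc(Cl)cc12` gives 223 nM

In a functional assay for antagonist activity at Oxoeicosanoid receptor 1 (Homo sapiens), read by fluorescence and calcium flux, with stated times of 2 min and 1 min (on this read-out higher numbers stand for weaker inhibition and lower numbers for stronger inhibition), compound 2 stands lowest of the three measured compounds, with compound 1 nearest and compound 3 furthest. Compound 4 `C[C@@H](CC(=O)O)CC(=O)c1c([C@H](O)CCCCCc2ccccc2)n(C)c2ccc(Cl)cc12` is not yet measured. Its difference from compound 2: the two compounds have the same atoms and bonds and differ only in configuration as drawn: 2 of 2 stereo elements differ (all stereocentres are inverted: mirror images); a stereocentre at a saturated chain carbon is drawn S in compound 2 and R in compound 4; a stereocentre at a saturated chain carbon is drawn S in compound 2 and R in compound 4. Among the measured compounds shown here, the only measured step that bears on this is a 320-fold lower number from compound 1 to compound 2 (2.50 log units; beyond the scatter), which rests on (the fact that compounds 1 and 2 differ only in the configuration as drawn); that step already covers the inversion at the methyl-bearing chain carbon, and compound 4 inverts the carbinol carbon in addition. A large step upward is therefore expected in this assay, at least of the size seen there. Compound 4 is expected to give about 300 nM, within 40 nM to 3000 nM, an estimated step of a 790-fold higher number from compound 2 to compound 4 (2.90 log units; beyond the scatter).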

Compound 4, half-maximal inhibitory concentration: 750 nM
Beside the measured number, compound 4's estimate is 2.5-fold (0.40 log units) below it; the measured number falls inside the stated range.
By their numbers in this assay, from the lowest: compound 2; then compounds 1 and 3 (each within the scatter of the next); then compound 4.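

In this assay, the carbinol carbon can now be read on its own: with the methyl-bearing chain carbon held as in compound 1, inversion there gives a 6.3-fold higher number from compound 1 to compound 4 (0.80 log units; beyond the scatter). Inverting both stereocentres gives a 2000-fold higher number from compound 2 to compound 4 (3.30 log units; beyond the scatter), so both centres count in this series, and the full mirror image stands well apart from compound 2.

On these data alone, the carbinol inversion is read only with the methyl-bearing carbon as in compound 1, so its size with that carbon as in compound 2 stays open. Also open, as far as these compounds go, is how a methyl ether in place of the hydroxyl would read.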